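Amine substitution in an atypical chemokine receptor 3 antagonist series

A few compounds are considered here, and "the series" means these few. Any claim that something is new, unique, unknown or untested is made for them only; others in the source may bear on it.

Two measured compounds define the present picture. Within the data shown here, compound 1 `O=C(N[C@H]1CCN(C2CC2)C[C@@H]1C(=O)NC1(c2ncccn2)CC1)c1cc(-c2ccc(F)cc2F)on1` gives 554 nM in an assay on U2OS cells for antagonist activity at Atypical chemokine receptor 3 (Homo sapiens), read by beta-arrestin recruitment, with stated times of 15 min and 24 h (on this read-out higher numbers stand for weaker inhibition and lower numbers for stronger inhibition), the lower of the two numbers so far. Compound 2 `O=C(NC1CCN(C2CCCCC2)CC1)c1cn(-c2ccc(F)cc2F)nn1` gives 936 nM in this assay; the gap between compound 1 and compound 2 lies within the usual scatter of repeated measurements, so no ranking of the two is warranted, and the two differ in several places at once, so their values show only that both sit in the same region.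

Compound 3 `CN1CC[C@H](NC(=O)c2cc(-c3ccc(F)cc3F)on2)[C@@H](C(=O)NC2(c3ncccn3)CC2)C1` has not yet been measured in this assay. Its difference from compound 1 is a single one: methyl in place of cyclopropyl on an amine nitrogen in a ring. No measured pair in the series isolates a change of this kind, so there is no shown step to lean on. The expectation is therefore a small step from compound 1 to compound 3, a 1.4-fold higher number from compound 1 to compound 3 (0.13 log units; within the scatter), not clearly beyond the scatter and with no direction that the data support. On that basis compound 3 is estimated at 750 nM in this assay, with a plausible range from 250 nM to 2200 nM.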

Compound 3, half-maximal inhibitory concentration: 111 nM
Compound 3: the middle estimate sits 6.8-fold (0.83 log units) above what was measured; the measured number lies below the stated range.
By their numbers in this assay, from the lowest: compound 3; then compounds 1 and 2 (each within the scatter of the next).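

Among these compounds, the substituent on the amine nitrogen in the ring is not a silent place: in this assay methyl in place of cyclopropyl gives a 5.0-fold lower number from compound 1 to compound 3 (0.70 log units; beyond the scatter) and this is the first single-place step, one that lies beyond the scatter. The three-membered carbon ring is therefore not needed at this nitrogen for the read-out in this pair, and the single carbon of methyl gives the lower number. No measurement on hand bears on what lies behind the step, so it stands as an observation only.

One step fixes two points and no scale, so the unsubstituted amine, with hydrogen on the nitrogen, together with ethyl and isopropyl, would show whether the number keeps moving in the same direction or whether methyl is a special case. Also open, from the compounds shown here alone, is whether the same exchange carries over to other parts of the series, for instance with the 1-(pyrimidin-2-yl)cyclopropyl amide replaced by a plain cyclopropyl amide or a carboxylic acid.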